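The compounds below may be only part of what the source reports. "The series", "measured", "known", "first", "only" and "open" are said of these compounds alone.

Compound 1, `c1ccc(CCCNC2CCc3ccsc3CC2)cc1`: 5.1 nM
Compound 2, `CN(CCCc1ccccc1)C1CCc2ccsc2CC1`: 13 nM

Both were tested in an assay on membranes from liver for displacement of a labelled ligand from Sigma intracellular receptor 2 (Rattus norvegicus), read by scintillation counting, with a stated time of 120 min, in the presence of a further agent that is not named here; a lower number here means a stronger inhibitor, a higher number a weaker inhibitor. Within the data shown here, compound 2 has the higher of these two numbers; the only step that reaches it is a 2.5-fold higher number from compound 1 to compound 2 (0.41 log units; beyond the scatter), which came from methyl in place of hydrogen on an amine nitrogen, a modest change. Compound 3, `CCN(CCCc1ccccc1)C1CCc2ccsc2CC1`, is not yet measured; it differs from compound 2 by methyl in place of hydrogen on a saturated chain carbon bound to an amine nitrogen, so the group on the amine nitrogen grows from methyl to ethyl. Among the measured compounds shown here, only the step of a 2.5-fold higher number from compound 1 to compound 2 (0.41 log units; beyond the scatter) bears on this, and it was small, so a further small rise or no change beyond the scatter is expected, as a 1.5-fold higher number from compound 2 to compound 3 (0.19 log units; within the scatter). Compound 3 is estimated at 20 nM, within 8 nM to 50 nM.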

Compound 3, inhibition constant: 33 nM
Estimate against measurement, compound 3: 1.7-fold (0.22 log units) below, and the stated range covers the measured number.
By their numbers in this assay, from the lowest: compound 1; then compound 2; then compound 3.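

In this assay growing the group on the amine nitrogen from methyl to ethyl raises the number again (a 2.5-fold higher number from compound 2 to compound 3 (0.40 log units; beyond the scatter)), a second step of the same printed size as the one from hydrogen to methyl. Overall, ethyl in place of hydrogen on that nitrogen gives (a 6.5-fold higher number from compound 1 to compound 3 (0.81 log units; beyond the scatter)), so across these three compounds the number climbs with each added carbon. Nothing available explains this climb. From the compounds shown here alone, whether a longer chain such as propyl would continue the rise remains open. So does the effect of a ring such as cyclopropyl on this nitrogen.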